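Swapping para-bromo for trifluoromethyl on a weak inhibitor

This account rests on a few compounds, and the source may have more. Where it says the series, first, only, none or still open, it means among the compounds named here.

Measured compounds:
compound 1, `C#CCNC1CCc2c(SCCc3ccc(Br)cc3)cccc21`, 85300 nM
compound 2, `C#CCNC1CCc2c(SCCc3cccc(F)c3)cccc21`, 4300 nM

Compound 1 has the highest of the two numbers in an assay on isolated protein for inhibition of Amine oxidase [flavin-containing] B (Homo sapiens); on this read-out higher numbers stand for weaker inhibition and lower numbers for stronger inhibition; its nearest neighbour is compound 2, with a 20-fold lower number from compound 1 to compound 2 (1.30 log units; beyond the scatter). Compound 3 has the structure `C#CCNC1CCc2c(SCCc3ccc(C(F)(F)F)cc3)cccc21` and differs from compound 1 by trifluoromethyl in place of bromo on an aromatic carbon. Going by the values given here, the only measured step, a 20-fold lower number from compound 1 to compound 2 (1.30 log units; beyond the scatter), changes both the halogen and its place on the ring at once, so it does not directly address a change of the para substituent alone; it shows only that this region of the molecule can move the number strongly. Without a step that isolates the para substituent, the expectation for compound 3 is anchored on compound 1, with a small step of uncertain direction, a 1.4-fold lower number from compound 1 to compound 3 (0.15 log units; within the scatter). Compound 3 is therefore expected to give 60000 nM, within a range of 15000 nM to 250000 nM.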

Compound 3, half-maximal inhibitory concentration: 16100 nM
Beside the measured number, compound 3's estimate is 3.7-fold (0.57 log units) above it; the range from low to high includes it.
By their numbers in this assay, from the lowest: compound 2; then compound 3; then compound 1.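

With its place on the ring held fixed, the group alone moves the number: in this assay, trifluoromethyl in place of bromo gives a 5.3-fold lower number from compound 1 to compound 3 (0.72 log units; beyond the scatter). The earlier step from compound 1 changed the halogen and its place together, so it could not separate the two, whereas this pair shows that a new group para to a large group is enough to produce a modest step beyond the scatter. Nothing available here explains why the number falls with this exchange.

As far as these compounds go, it remains open how a methoxy group, a nitrile or plain hydrogen would read at this same place on the ring. From the compounds shown here alone, it is also open how much of a 20-fold lower number from compound 1 to compound 2 (1.30 log units; beyond the scatter) belongs to the change of halogen and how much to its new place.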